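Removing a Methoxy Group from a Weakly Cytotoxic Amide

The compounds below may be only part of what the source reports. "The series", "measured", "known", "first", "only" and "open" are said of these compounds alone.

Compound 1 `C=CC1=C(C(=O)Nc2ccccc2OC)C(c2ccc(F)cc2)OC1` and compound 2 `C=CC1=C(C(=O)Nc2ccccc2)C(c2ccc(F)cc2)OC1` share a core and differ in one place, namely (hydrogen in place of methoxy on an aromatic carbon). In a functional assay on QGY7701 cells (Homo sapiens) for cytotoxicity, read by MTT assay, with a stated time of 24 h (a lower number here means a stronger inhibitor, a higher number a weaker inhibitor), compound 1 gives 52800 nM, and compound 2 gives 46700 nM, so that the step of a 1.1-fold lower number from compound 1 to compound 2 (0.05 log units; within the scatter). Compound 3 `C=CC1=C(C(=O)NCCC)C(c2ccc(OC)c(OC)c2)OC1` differs from compound 1 in more than one place, and the difference between the two cores is not broken down here. In this assay compound 3 reaches only > 100000 nM, which is a limit of the assay and not a number (the limit of > 100000 nM in this assay, at which 1 of the 3 values shown sits). Compound 4 `C=CC1=C(C(=O)NCCC)C(c2ccc(OC)cc2)OC1` has not yet been measured in this assay and differs from compound 3 by hydrogen in place of methoxy on an aromatic carbon. This is the same kind of change as that from compound 1 to compound 2, though the surroundings differ: in compound 1 the leaving methoxy sits ortho to a large group, whereas in compound 3 it sits ortho to a methoxy group and meta to a large group. For compound 4 the expected step in this assay is a number no higher from compound 3 to compound 4 (the limit leaves the size open). That expectation rests on compound 3 sitting at the limit > 100000 nM. It also rests on the earlier step of a 1.1-fold lower number from compound 1 to compound 2 (0.05 log units; within the scatter), which changed little. Compound 4 is therefore estimated at 100000 nM, expected to fall between 50000 nM and 300000 nM.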

Compound 4, half-maximal inhibitory concentration: > 100000 nM
Compound 4: a limit, no number; the forecaster's own chance of this, stated with the estimate: 70%; the middle value lies on the limit itself.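

In this assay compound 4 gives > 100000 nM, which is a limit of the assay and not a number. Compound 3 stands at a limit too, so no step from compound 3 to compound 4 can be read: the limit of > 100000 nM in this assay, at which 2 of the 4 values shown sit.

The compounds shown leave open what size, if any, the change from methoxy to hydrogen has in this pair.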